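This account rests on a few compounds, and the source may have more. Where it says the series, first, only, none or still open, it means among the compounds named here.

Of the compounds shown here, two of the same core have been tested in a functional assay on HCT-116 cells (Homo sapiens) for inhibition, read by sulforhodamine B assay, with a stated time of 48 h (a higher number here means that more compound is tolerated, a lower number that less compound is tolerated), and both reached only the limit of the assay rather than a number. Compound 1 `COc1cc(-c2nn(-c3cccc(NC(=O)c4cccc(C(F)(F)F)c4)c3)cc2-c2ccncc2)ccc1Cl` carries a 3-(trifluoromethyl)phenyl on its carbonyl carbon. In this assay compound 1 gives > 50000 nM, which is a limit of the assay and not a measured number. Compound 2 `O=C(Nc1cccc(-n2cc(-c3ccncc3)c(-c3ccc(Cl)c(O)c3)n2)c1)Nc1ccc(Cl)c(C(F)(F)F)c1` is the related urea with a hydroxy in place of the methoxy. In this assay compound 2 gives > 32500 nM, again a limit rather than a number. So compound 1 stands at one limit, as shown by the limit of > 50000 nM in this assay, at which 1 of the 2 values shown sits, and compound 2 at the other, as shown by the limit of > 32500 nM in this assay, at which 1 of the 2 values shown sits.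

Compound 3 `COc1cc(-c2nn(-c3cccc(NC(=O)Nc4ccc(Cl)c(Cl)c4)c3)cc2-c2ccncc2)ccc1Cl` has not yet been measured. It differs from compound 1 in one place ((3,4-dichlorophenyl)amino in place of 3-(trifluoromethyl)phenyl on a carbonyl carbon). Among the compounds with values here, no measured step matches this change, and the two values at hand are both limits, so no direction can be read from them. The step from compound 1 to compound 3 is expected to be a number no higher from compound 1 to compound 3 (the limit leaves the size open), that is, none beyond the scatter, with the result most likely again a limit. For compound 3 the estimate in this assay is 50000 nM, within the range 20000 nM to 100000 nM.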

Compound 3, concentration lethal to 50% of the cells: > 50000 nM
Compound 3 gave a limit, no number; the forecaster's own chance of this, stated with the estimate: 75%; the middle value sits exactly at the limit.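

In this assay, within the data shown here, compound 3 ends at a limit of the assay, as compound 1 does, so no step between these two compounds can be read. The compounds shown leave open what number any of the three would give, and whether (3,4-dichlorophenyl)amino in place of 3-(trifluoromethyl)phenyl changes the result at all.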